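Swapping the Aromatic Ether Cap on a Macrolide

The compounds below may be only part of what the source reports. "The series", "measured", "known", "first", "only" and "open" are said of these compounds alone.

Compound 1 `CC[C@@H]1/C=C(\C)C[C@H](C)C[C@H](OC)[C@H]2O[C@@](O)(C(=O)C(=O)N3CCCC[C@H]3C(=O)O[C@H](/C(C)=C/[C@@H]3CC[C@@H](Oc4cccc(O)c4)[C@H](OC)C3)[C@H](C)[C@@H](O)CC1=O)[C@H](C)C[C@@H]2OC` is tested in a functional assay on cells for inhibition, with Murine T-cell line (Mus musculus) as the target (on this read-out higher numbers stand for weaker inhibition and lower numbers for stronger inhibition), where compound 1 gives 1.7 nM. Compound 2 `CC[C@@H]1/C=C(\C)C[C@H](C)C[C@H](OC)[C@H]2O[C@@](O)(C(=O)C(=O)N3CCCC[C@H]3C(=O)O[C@H](/C(C)=C/[C@@H]3CC[C@@H](O)[C@H](Oc4ccccc4)C3)[C@H](C)[C@@H](O)CC1=O)[C@H](C)C[C@@H]2OC` gives 3.2 nM in this assay, and the two values lie within the usual scatter of each other, so compound 1 stands alongside compound 2 rather than apart from it. Compound 3 `CC[C@@H]1/C=C(\C)C[C@H](C)C[C@H](OC)[C@H]2O[C@@](O)(C(=O)C(=O)N3CCCC[C@H]3C(=O)O[C@H](/C(C)=C/[C@@H]3CC[C@@H](Oc4ccc(C)cc4)[C@H](OC)C3)[C@H](C)[C@@H](O)CC1=O)[C@H](C)C[C@@H]2OC` differs from compound 1 in one place: 4-methylphenyl in place of 3-hydroxyphenyl on an oxygen on a saturated carbon. Going by the values given here, no measured pair here shows what such a change does. Only a small step is expected, a 1.5-fold higher number from compound 1 to compound 3 (0.17 log units; within the scatter), possibly none beyond the scatter. Compound 3 is estimated at 2.5 nM, within a range from 1 nM to 6.5 nM.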

Compound 3, half-maximal inhibitory concentration: 2.7 nM
Estimate against measurement, compound 3: 1.1-fold (0.03 log units) below; the measured number falls inside the stated range.
By their numbers in this assay, from the lowest: compounds 1, 3 and 2 (each within the scatter of the next).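

Putting 4-methylphenyl in place of 3-hydroxyphenyl on this oxygen gives a 1.6-fold higher number from compound 1 to compound 3 (0.20 log units; within the scatter) and so leaves the two compounds indistinguishable on this read-out. At this position, then, an aromatic group with 0 hydrogen-bond donors and 0 hydrogen-bond acceptors reads the same as one with 1 of each. Going by these compounds, whether the same holds for a phenyl group bearing an amine or a carboxylic acid stays open. No measurement shown gives a reason for this result.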